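The compounds below may be only part of what the source reports. "The series", "measured", "known", "first", "only" and "open" are said of these compounds alone.

Working notes on the series.

Compound 1 `O=C(Nc1cccc(-c2oc3cc(-c4ccc(F)cc4)ccc3c(=O)c2O)c1)c1ccc(F)cc1F` gives 13500 nM in a functional assay on MCF7 cells (Homo sapiens) for antiproliferative activity, read by CCK-8 assay, with a stated time of 72 h; on this read-out higher numbers stand for weaker inhibition and lower numbers for stronger inhibition. Compound 2 `Cc1ccccc1C(=O)Nc1cccc(-c2oc3cc(-c4ccc(F)cc4)ccc3c(=O)c2O)c1` gives 2280 nM in this assay, which is a 5.9-fold lower number from compound 1 to compound 2 (0.77 log units; beyond the scatter). Going by the values given here, of the two numbers measured so far, compound 2 stands at the lower one, with compound 1 as the only comparator.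

Compound 3 `CCc1ccc(C(=O)Nc2cccc(-c3oc4cc(-c5ccc(F)cc5)ccc4c(=O)c3O)c2)cc1` is not yet measured in this assay. It differs from compound 2 by 4-ethylphenyl in place of 2-methylphenyl on a carbonyl carbon. Among the compounds with values here, the only measured step touching this position is the one from compound 1 to compound 2, where an exchange of the aryl group on the carbonyl carbon gave a 5.9-fold lower number from compound 1 to compound 2 (0.77 log units; beyond the scatter); that step shows the position is sensitive, but it involved a different pair of groups and gives no direction for the present change. The expected step is therefore small, a 1.1-fold higher number from compound 2 to compound 3 (0.04 log units; within the scatter), with wide uncertainty. For compound 3 the estimated value in this assay is 2500 nM, within a range of 600 nM to 10000 nM.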

Compound 3, half-maximal inhibitory concentration: 22800 nM
Compound 3: middle estimate off by 9.1-fold (0.96 log units), on the low side, and the stated range ends below it.
By their numbers in this assay, from the lowest: compound 2; then compounds 1 and 3 (each within the scatter of the next).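

The position on the carbonyl carbon now shows a large step upward as well as the earlier one downward: 4-ethylphenyl in place of 2-methylphenyl gives a clear loss (a 10-fold higher number from compound 2 to compound 3 (1.00 log units; beyond the scatter)). 4-Ethylphenyl in place of 2,4-difluorophenyl leaves the two compounds unseparated (a 1.7-fold higher number from compound 1 to compound 3 (0.23 log units; within the scatter)), so among these three aryl groups only the 2-methylphenyl of compound 2 stands apart. Nothing available bears on why this exchange has such an effect.

From the compounds shown here alone, it remains open whether the low number of compound 2 is specific to 2-methylphenyl or can also be reached by other groups on this carbonyl carbon. A plain phenyl, a methoxyphenyl or an aminophenyl at this place would help to settle that.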